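This account rests on a few compounds, and the source may have more. Where it says the series, first, only, none or still open, it means among the compounds named here.

Compound 1, `O=C(Oc1ccc2ccc(=O)oc2c1CN1CCc2ccccc2C1)c1ccccc1`, gives in an ADME assay on MT4 cells (Homo sapiens) for cytotoxicity, read by MTT assay, with a stated time of 96 h (a higher number here means that more compound is tolerated, a lower number that less compound is tolerated), the result > 100000 nM, which is a limit of the assay rather than a number.
Compound 2, `Cc1cc(=O)oc2c(CN3CCc4ccccc4C3)c(O)ccc12`, gives in this assay the result > 100000 nM, again a limit of the assay and not a number.

Compound 2 thus stands exactly where the only other result stands: the limit of > 100000 nM in this assay, at which 2 of the 2 values shown sit. Among the compounds with values here, because both results are limits, the two values show only that neither compound reached a half-maximal toxic effect within the tested range; they say nothing about any difference between the two.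

Compound 3, `CCCOc1ccc2c(C)cc(=O)oc2c1CN1CCc2ccccc2C1`, has not been measured. It differs from compound 2 in one place: propyl in place of hydrogen on an oxygen on an aromatic ring. Within the data shown here, no measured pair shows what this change does in this assay, so there is no measured step to lean on. Given that compound 2 sits at a limit, the step is expected to be none beyond the scatter, with the new compound most likely again reported only as a limit. Compound 3 is therefore estimated at 100000 nM, with a range from 40000 nM to 300000 nM, which means an expected step of a number no higher from compound 2 to compound 3 (the limit leaves the size open).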

Compound 3, half-maximal cytotoxic concentration: > 100000 nM
Compound 3 was reported as a limit; the forecaster's own chance of this, stated with the estimate: 75%; the middle value lies on the limit itself.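

Compound 2 and compound 3 are both reported in this assay only as limits, so no step can be read between them, and the change from hydroxy to propoxy has no readable size. The compounds shown leave open at what concentration, if any, each would reach a half-maximal toxic effect on these cells.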